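Swapping the thiophene of compound 1 for a dichlorophenyl ring

The compounds below may be only part of what the source reports. "The series", "measured", "known", "first", "only" and "open" are said of these compounds alone.

Measured compounds:
compound 1 `CCOC(=O)c1cnc(-c2cccs2)nc1NN1C(=O)C=C(C)C1=O`: 20 nM
compound 2 `CCOC(=O)c1cnc(-c2cccc(OC)c2)nc1NN1C(=O)C=C(C)C1=O`: 5000 nM
compound 3 `CCOC(=O)c1cnc(-c2cc3ccccc3s2)nc1NN1C(=O)C=C(C)C1=O`: 4000 nM

Of the compounds shown here, three sharing one core have been tested in a functional assay on Jurkat cells for inhibition of nuclear factor NF-kappa-B complex (Homo sapiens) (a lower number here means a stronger inhibitor, a higher number a weaker inhibitor), and compound 1 gives the lowest number of the three, with 20 nM. Compound 2 sits furthest from it: a 250-fold higher number from compound 1 to compound 2 (2.40 log units; beyond the scatter). Compound 3 lies close behind: a 200-fold higher number from compound 1 to compound 3 (2.30 log units; beyond the scatter). Compounds 2 and 3 are essentially level with each other, as a 1.3-fold lower number from compound 2 to compound 3 (0.10 log units; within the scatter) shows.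

Compound 4 `CCOC(=O)c1cnc(-c2cc(Cl)cc(Cl)c2)nc1NN1C(=O)C=C(C)C1=O` has not yet been tested in this assay. It differs from compound 1 in a single place: 3,5-dichlorophenyl in place of thiophen-2-yl on an aromatic carbon. The two measured steps that bear on this change are those from compound 1 to compound 2 and from compound 1 to compound 3, both of which replaced the thiophen-2-yl with a larger aromatic group and both of which were large and in the same direction. The step to compound 4 is therefore expected to be large and upward as well, roughly a 150-fold higher number from compound 1 to compound 4 (2.18 log units; beyond the scatter). Compound 4 is estimated at 3000 nM, within a range of 500 nM to 15000 nM.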

Compound 4, half-maximal inhibitory concentration: 300 nM
Compound 4: the middle estimate sits 10-fold (1.00 log units) above what was measured, and the stated range ends above it.
By their numbers in this assay, from the lowest: compound 1; then compound 4; then compounds 3 and 2 (each within the scatter of the next).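

In this assay, placing 3,5-dichlorophenyl on the aromatic carbon between two ring nitrogen atoms still gives a 15-fold higher number from compound 1 to compound 4 (1.18 log units; beyond the scatter) and leaves the thiophen-2-yl of compound 1 with the lowest number of the four compounds. The replacements at this position are nevertheless not equivalent, with a 13-fold lower number from compound 3 to compound 4 (1.12 log units; beyond the scatter) and a 17-fold lower number from compound 2 to compound 4 (1.22 log units; beyond the scatter) among the three groups that replace thiophen-2-yl. A six-membered aromatic ring of carbon only therefore does not by itself give a number as high as that of compound 2, although no available evidence accounts for these differences. From the compounds shown here alone, it remains open how thiophen-3-yl, furan-2-yl or unsubstituted phenyl would compare at this position. A single chlorine, or a 3,5-dimethylphenyl group, would show whether both chlorine atoms are needed for the number seen with compound 4.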